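The source may report more compounds than this note shows. Statements on the series, on what has been measured and on what is new or still open speak of the compounds shown alone.

Compounds measured so far in an ADME assay on BJ cells (Homo sapiens) for antiproliferative activity, with a stated time of 72 h; a lower number here means that less compound is needed, a higher number that more compound is needed for the effect:

Compound 1 `COc1ccc(-c2cc(=O)c3c(OC)cc(OC)cc3n2Cc2ccccc2)cc1` gives > 34400 nM, a limit of the assay rather than a number.
Compound 2 `COc1ccc(-c2cc(=O)c3c(OC)cc(OC)cc3n2S(=O)(=O)c2c(F)c(F)c(F)c(F)c2F)cc1` gives > 34400 nM, again a limit.
Compound 3 `COc1ccc(-c2cc(=O)c3c(OC)cc(OC)cc3n2S(=O)(=O)c2cccc(Br)c2)cc1` gives > 58600 nM, also a limit.

Compound 3 therefore has no measured number in this assay, only a limit, and the same holds for the two other compounds shown: two of the values sit at the limit of > 34400 nM in this assay, at which 2 of the 3 values shown sit, and one at the limit of > 58600 nM in this assay, at which 1 of the 3 values shown sits. The step that the two limits leave unreadable from compound 1 to compound 3 and the step that the two limits leave unreadable from compound 2 to compound 3 both run between limits and cannot be read in size or direction.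

Compound 4 `COc1ccc(-c2cc(=O)c3c(OC)cc(OC)cc3n2S(=O)(=O)c2ccc(Br)s2)cc1` differs from compound 3 by 5-bromothiophen-2-yl in place of 3-bromophenyl on a sulfonyl sulfur. Going by the values given here, neither measured step gives a readable size for a change on the sulfonyl sulfur, since all three values shown are limits; the most that can be said is that no compound so far has reached a measurable concentration. Compound 4 is estimated at 50000 nM, with a range from 15000 nM to 200000 nM. The step of an at least 1.1-fold lower number from compound 3 to compound 4 (0.06 log units; that floor lies within the scatter) is expected to be small, and a further limit rather than a number is the more likely outcome.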

Compound 4, half-maximal effective concentration: > 48200 nM
Compound 4: only a limit was reported (the forecaster's own chance of this, stated with the estimate: 80%); the middle value lies beyond the limit too.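

In this assay compound 4 gives > 48200 nM, which is a limit and not a number. Its steps from compound 1, compound 2 and compound 3 all run between limits, so none can be read in size or direction. The compounds shown leave open whether any group on the sulfonyl sulfur gives a measurable concentration in this assay.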